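The source may report more compounds than this note shows. Statements on the series, on what has been measured and on what is new or still open speak of the compounds shown alone.

Measured so far in an ADME assay on cells (Astrocyte, Rattus norvegicus, strain Wistar) for inhibition, read by sulforhodamine B assay, with a stated time of 72 h; on this read-out lower numbers stand for higher toxicity in this test and higher numbers for lower toxicity in this test:
compound 1 `O=C(/C=C/c1ccc([N+](=O)[O-])o1)c1ccc(-n2ccnc2)cc1`: 45300 nM
compound 2 `O=C(/C=C/c1ccc([N+](=O)[O-])o1)c1ccc(N2CCCC2)cc1`: 65800 nM

For the measured compounds named here, with only two numbers in hand, compound 2 at 65800 nM lies within the scatter of compound 1, so no order can be drawn between them.

The next change leads to compound 3 `O=C(/C=C/c1ccc([N+](=O)[O-])o1)c1ccc(C2CCCCC2)cc1`, with cyclohexyl in place of pyrrolidin-1-yl on an aromatic carbon.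

Going by the values given here, one measured step bears on this change. It altered the group at the same place, with pyrrolidin-1-yl in place of 1H-imidazol-1-yl, and gave a 1.5-fold higher number from compound 1 to compound 2 (0.16 log units; within the scatter). Among the compounds with values here, that is thin evidence: it is a single step, and no measured compound has a ring of carbon only at this place. Even so, with compound 2 reached through a 1.5-fold higher number from compound 1 to compound 2 (0.16 log units; within the scatter), no step beyond the scatter is expected in this assay, in either direction.

The expected step is a 1.2-fold lower number from compound 2 to compound 3 (0.08 log units; within the scatter). For compound 3 the estimated value is 55000 nM, with an expected range from 25000 nM to 110000 nM.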

Compound 3, half-maximal cytotoxic concentration: 57200 nM
For compound 3 the middle estimate is 1.0-fold (0.02 log units) below the measured one; measured number inside the range.
By their numbers in this assay, from the lowest: compounds 1, 3 and 2 (each within the scatter of the next).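

In this assay, cyclohexyl in place of pyrrolidin-1-yl gives a 1.2-fold lower number from compound 2 to compound 3 (0.06 log units; within the scatter), and cyclohexyl in place of 1H-imidazol-1-yl gives a 1.3-fold higher number from compound 1 to compound 3 (0.10 log units; within the scatter). Cyclohexyl is the first ring of carbon only at this position, on an aromatic carbon para to a large group, and it carries no hydrogen-bond acceptor, yet all three compounds remain within the scatter of one another, so among these three a ring nitrogen at this position makes no readable difference to the read-out. Nothing measured here offers an explanation for this result.

Going by these compounds, all three groups at this position are rings, so it remains open whether an open chain such as n-butyl, an amine such as dimethylamino or a carboxylic acid would give a step beyond the scatter. On these data alone, all three compounds also share the core of compound 1, so it remains open whether the same picture would hold with a nitrile in place of the nitro group on that core.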